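Trimming the pyrazole from a potent LRRK2 binder

The source may report more compounds than this note shows. Statements on the series, on what has been measured and on what is new or still open speak of the compounds shown alone.

Measured compounds:
compound 1, `C[C@@H]1CCCN1c1c(C#N)c2c(N)nc(Nc3cn[nH]c3)nc2n1C`: 0.2 nM
compound 2, `Cn1c(NCc2ccccc2F)c(C#N)c2c(N)ncnc21`: 145 nM

In an assay on isolated protein for binding affinity to Leucine-rich repeat serine/threonine-protein kinase 2 (Homo sapiens), read by TR-FRET and LanthaScreen, with a stated time of 2 h (a lower number here means a stronger inhibitor, a higher number a weaker inhibitor), compound 1 gives 0.2 nM, the lowest of the two numbers shown. Its nearest neighbour is compound 2, which gives 145 nM, a gap well beyond the scatter; the two structures differ in several places, so only their values can be compared.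

Compound 3, `C[C@@H]1CCCN1c1c(C#N)c2c(N)nc(N)nc2n1C`, has not yet been measured. It follows from compound 1 by the change (hydrogen in place of 1H-pyrazol-4-yl on a nitrogen on an aromatic ring). Among the compounds with values here, no step between measured compounds covers this change, so the expectation rests on the wide gap between compound 1 and compound 2. The step from compound 1 to compound 3 is expected to be a clear loss of affinity, a 200-fold higher number from compound 1 to compound 3 (2.30 log units; beyond the scatter). Compound 3 is therefore estimated at 40 nM, within a range of 4 nM to 400 nM.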

Compound 3, inhibition constant: 6 nM
Beside the measured number, compound 3's estimate is 6.7-fold (0.82 log units) above it, within the range that was stated.
By their numbers in this assay, from the lowest: compound 1; then compound 3; then compound 2.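

Replacing the 1H-pyrazol-4-yl with hydrogen on the nitrogen on the aromatic ring, which turns (1H-pyrazol-4-yl)amino into amino, gives a 30-fold higher number from compound 1 to compound 3 (1.48 log units; beyond the scatter) in this assay, so this single change accounts for a large loss of affinity. Even so, compound 3 still gives 6 nM in this assay with a plain amino group at this place, so the low number of compound 1 does not rest on the 1H-pyrazol-4-yl alone. Nothing available explains the size of this step.

The compounds shown leave open how much of the step a simpler group on that nitrogen, such as a methyl, could recover. They also leave open whether another aromatic ring, such as a phenyl or a pyridine, could take the place of the 1H-pyrazol-4-yl and match compound 1.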